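The compounds below may be only part of what the source reports. "The series", "measured", "known", "first", "only" and "open" are said of these compounds alone.

Measured so far:
compound 1 `CN(C)CCn1cnnc1-c1cc(Oc2ccc(NC(=O)N/N=C/c3cccc(Br)c3)cc2F)ccn1`, 4230 nM
compound 2 `CN(C)CCn1cnnc1-c1cc(Oc2ccc(NC(=O)N/N=C/c3ccc(O)c(O)c3)cc2F)ccn1`, "not determined" (no result reported)
compound 3 `CN(C)CCn1cnnc1-c1cc(Oc2ccc(NC(=O)N/N=C/c3c(O)ccc4ccccc34)cc2F)ccn1`, 3250 nM

In an ADME assay on WI-38 cells (Homo sapiens) for cytotoxicity, read by MTT assay, with a stated time of 72 h (on this read-out higher numbers stand for weaker inhibition and lower numbers for stronger inhibition), compound 1 gives the higher of the two numbers available; its nearest neighbour is compound 3, and the change a 1.3-fold lower number from compound 1 to compound 3 (0.11 log units; within the scatter) stays within the scatter. Compound 4 `CN(C)CCn1cnnc1-c1cc(Oc2ccc(NC(=O)N/N=C/c3c[nH]c4ccccc34)cc2F)ccn1` differs from compound 1 in one place: 1H-indol-3-yl in place of 3-bromophenyl on a carbon with a double bond to nitrogen. Among the measured compounds shown here, the only comparable step, a 1.3-fold lower number from compound 1 to compound 3 (0.11 log units; within the scatter), replaced the same 3-bromophenyl with another ring system on the carbon with a double bond to nitrogen and moved the number very little. No step beyond the scatter is therefore expected here, and the shift a 1.1-fold lower number from compound 1 to compound 4 (0.02 log units; within the scatter) is expected to be small. Compound 4 is thus estimated to give 4000 nM in this assay, within the range 1500 nM to 10000 nM.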

Compound 4, half-maximal inhibitory concentration: 3620 nM
The estimate for compound 4 lay 1.1-fold (0.04 log units) above the measured number, and the stated range covers the measured number.
By their numbers in this assay, from the lowest: compounds 3, 4 and 1 (each within the scatter of the next).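

In this assay, the 1H-indol-3-yl group, with its five-membered aromatic ring and hydrogen-bond donor, gives a 1.2-fold lower number from compound 1 to compound 4 (0.07 log units; within the scatter) and a 1.1-fold higher number from compound 3 to compound 4 (0.05 log units; within the scatter) on the carbon with a double bond to nitrogen. Three different aromatic groups at this place, including one with a ring containing a hetero atom, now give numbers within the scatter of one another. Nothing available explains this lack of separation. The compounds shown leave open whether a carboxylic acid or a saturated ring such as morpholine at this place would shift the number beyond the scatter.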